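Three Amides of One Acid and an Expected Fourth

The compounds below may be only part of what the source reports. "The series", "measured", "known", "first", "only" and "open" are said of these compounds alone.

Compound 1 `COc1cc2c(cc1OC)C(CC(=O)O)CC2`: 44%
Compound 2 `CCCCNC(=O)CC1CCc2cc(OC)c(OC)cc21`: 39.4%
Compound 3 `COc1cc2c(cc1OC)C(CC(=O)NC1CCCCC1)CC2`: 44.7%

In a functional assay on the whole organism (strain Swiss albino) for inhibition, with Mus musculus as the target, in the writhing test, with stated times of 60 min and 15 min, at a dose of 100 mg/kg by the oral route (a lower number here means less inhibition, a higher number more inhibition at the dose given (going by the name of the read-out)), compound 2 shows the lowest of the three numbers, but its neighbours lie within the scatter: a number 4.6 percentage points lower from compound 1 to compound 2 (within the scatter) and a number 5.3 percentage points higher from compound 2 to compound 3 (within the scatter). Compound 4 `COc1cc2c(cc1OC)C(CC(=O)N1CCCC1)CC2` has not yet been measured; it differs from compound 2 in one place, (pyrrolidin-1-yl in place of butylamino on a carbonyl carbon). The two steps that bear on this change, the exchange of hydroxy for butylamino and of butyl for cyclohexyl, both stayed within the scatter, so a change of the group on the carbonyl carbon has so far left the read-out where it was. Compound 4 is therefore expected to give 42% (range 30% to 54%), a step of a number 2.6 percentage points higher from compound 2 to compound 4 (within the scatter) that is expected to stay within the scatter.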

Compound 4, a percentage reported as inhibition, in the whole organism at one dose (the size of the read-out at that dose, not a potency): 19.2%
Compound 4: the middle estimate sits 22.8 percentage points above what was measured, and the stated range ends above it.
By their numbers in this assay, from the lowest: compound 4; then compounds 2, 1 and 3 (each within the scatter of the next).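

In this assay the group on the carbonyl carbon turns out to matter after all: pyrrolidin-1-yl gives a number 20.2 percentage points lower from compound 2 to compound 4 (beyond the scatter), and the same exchange gives a number 25.5 percentage points lower from compound 3 to compound 4 (beyond the scatter) and a number 24.8 percentage points lower from compound 1 to compound 4 (beyond the scatter). Butylamino and pyrrolidin-1-yl have the same heavy-atom count, and among the two amides that differ from compound 4 at this place, compound 2 and compound 3 both keep the amide hydrogen, which compound 4 lacks. No available data give a reason for this drop. From the compounds shown here alone, whether it goes with the missing amide hydrogen or with the ring closed through the nitrogen stays open. Diethylamino on the same carbonyl carbon, which has no amide hydrogen and no ring, would help to separate the two.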